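A Sulfonyl Link in Place of Benzyl

The source may hold more compounds than are shown below. What is called first, only, known or untested is meant among the compounds shown, and "the series" means these compounds.

- Compound 1 `COc1ccc(S(=O)(=O)N2CCc3cccc(NC(=O)Oc4ccccc4)c32)cc1`: > 10000 nM
- Compound 2 `COc1ccc(S(=O)(=O)N2CCc3cccc(NC(=O)c4ccc(F)cc4)c32)cc1`: 45 nM
- Compound 3 `COc1ccc(S(=O)(=O)N2CCc3cccc(NCc4ccccc4)c32)cc1`: > 10000 nM

In a functional assay on MKN-45 cells (Homo sapiens) for cytotoxicity (a lower number here means a stronger inhibitor, a higher number a weaker inhibitor), compound 3 stands at > 10000 nM, which is a limit and not a number. Compound 1 also shows only a limit, > 10000 nM. Only compound 2 gives a true number, 45 nM.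

Compound 4 `COc1ccc(S(=O)(=O)N2CCc3cccc(NS(=O)(=O)c4ccccc4)c32)cc1` has not been measured. It carries phenylsulfonyl in place of benzyl on a nitrogen on an aromatic ring. The closest measured change is an at least 220-fold higher number from compound 2 to compound 3 (2.34 log units; beyond the scatter), which is beyond the scatter and arises at this same nitrogen. Another large change is an at least 220-fold lower number from compound 1 to compound 2 (2.34 log units; beyond the scatter), so this part of the molecule can matter greatly. Yet compound 1 is a warning that replacing benzyl need not help, as a step that the two limits leave unreadable from compound 1 to compound 3 shows. A drop is expected, but a smaller one than those large steps. The expected change is an at least 6.6-fold lower number from compound 3 to compound 4 (0.82 log units; beyond the scatter). Compound 4 is estimated at 1500 nM, with an expected range of 100 nM to 15000 nM.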

Compound 4, half-maximal inhibitory concentration: 562 nM
Compound 4: middle estimate off by 2.7-fold (0.43 log units), on the high side; the measured number falls inside the stated range.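

In this assay, phenylsulfonyl on this nitrogen shows that a group other than (4-fluorophenyl)carbonyl can give a real number, with an at least 17-fold lower number from compound 3 to compound 4 (1.25 log units; beyond the scatter) and an at least 17-fold lower number from compound 1 to compound 4 (1.25 log units; beyond the scatter). It does not match that group, however, as the change gives a 12-fold higher number from compound 2 to compound 4 (1.10 log units; beyond the scatter). The first two steps give only minimum sizes, because compound 1 and compound 3 both sit at a limit: the limit of > 10000 nM in this assay, at which 2 of the 4 values shown sit.

From the compounds shown here alone, compound 2 and compound 4 differ in both the linking group and the fluorine, so the share of each in that gap remains open. Benzoyl or 4-fluorophenylsulfonyl on this nitrogen would separate the two, since each changes only one of them relative to compound 2 or compound 4.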